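Methylsulfanyl in Place of Chloro: Expected Antiproliferative Potency

The source may report more compounds than this note shows. Statements on the series, on what has been measured and on what is new or still open speak of the compounds shown alone.

Compound 1 `COc1cc(-n2ncnc2-c2ccc(OC(C)C)cc2)cc(OC)c1OC` gives 800 nM in a functional assay on K562 cells (Homo sapiens) for antiproliferative activity, read by MTT assay, with a stated time of 72 h; a higher number here means a weaker inhibitor, a lower number a stronger inhibitor.
Compound 2 `COc1cc(-n2ncnc2-c2ccc(F)cc2)cc(OC)c1OC` reaches only the limit > 10000 nM in this assay.
Compound 3 `COc1cc(-n2ncnc2-c2ccc(Cl)cc2)cc(OC)c1OC` likewise reaches only the limit > 10000 nM.

Compound 3 thus stands at the weak end of what is shown: its value is a limit, not a number, and it sits at the limit of > 10000 nM in this assay, at which 2 of the 3 values shown sit. Compound 4 `COc1cc(-n2ncnc2-c2ccc(SC)cc2)cc(OC)c1OC` differs from compound 3 by methylsulfanyl in place of chloro on an aromatic carbon. The measured steps at this position are an at least 12-fold higher number from compound 1 to compound 3 (1.09 log units; beyond the scatter) and an at least 12-fold higher number from compound 1 to compound 2 (1.09 log units; beyond the scatter), both large losses when isopropoxy is replaced by a halogen, while a step that the two limits leave unreadable from compound 2 to compound 3. Within the data shown here, no measured step covers methylsulfanyl itself. Some recovery of potency is expected because compound 1, the one non-halogen here, gave 800 nM. Compound 4 is therefore estimated at 3000 nM (range 800 nM to 10000 nM), an expected step of an at least 3.3-fold lower number from compound 3 to compound 4 (0.52 log units; beyond the scatter).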

Compound 4, half-maximal inhibitory concentration: 340 nM
The estimate for compound 4 lay 8.8-fold (0.95 log units) above the measured number, and the stated range ends above it.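

In this assay, compound 2 and compound 3 give limits, not numbers: the limit of > 10000 nM in this assay, at which 2 of the 4 values shown sit. Methylsulfanyl brings activity back at this position, with an at least 29-fold lower number from compound 3 to compound 4 (1.46 log units; beyond the scatter) and an at least 29-fold lower number from compound 2 to compound 4 (1.46 log units; beyond the scatter). It also improves on the isopropoxy group, with a 2.4-fold lower number from compound 1 to compound 4 (0.37 log units; beyond the scatter), so isopropoxy is not required for activity on this core.

The compounds shown leave open whether the gain depends on the sulfur or would appear with other non-halogen groups. An amine, or a longer chain such as ethylsulfanyl, at this position would begin to answer that.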